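Varied groups at a saturated ring carbon of one core

The source may report more compounds than this note shows. Statements on the series, on what has been measured and on what is new or still open speak of the compounds shown alone.

Compound 1 `Cc1nn(-c2ncnc3nc[nH]c23)c2c1C(c1ccc(F)cc1Cl)CC(=O)N2`: 9 nM
Compound 2 `Cc1nn(-c2ncnc3nc[nH]c23)c2c1C(C(=O)N(C)c1nccs1)CC(=O)N2`: 18 nM
Compound 3 `Cc1nn(-c2ncnc3nc[nH]c23)c2c1C(C(=O)Nc1ccccc1)CC(=O)N2`: 10 nM

In a functional assay on HEK293 cells for agonist activity at G-protein coupled receptor 39 (Homo sapiens), read by scintillation proximity assay and inositol phosphate accumulation, with a stated time of 75 min, in the presence of a further agent that is not named here (on this read-out higher numbers stand for an effect only at larger amounts of compound and lower numbers for an effect already at smaller amounts), compound 3 gives 10 nM, the second highest of the three numbers; compound 1 stands nearest and compound 2 furthest, both within the scatter. Compound 4 `Cc1nn(-c2ncnc3nc[nH]c23)c2c1C(OCc1ccc(F)cc1)CC(=O)N2` differs from compound 3 in one place: (4-fluorobenzyl)oxy in place of phenylcarbamoyl on a saturated ring carbon. The measured steps that bear on this change all concern the same saturated ring carbon: a 1.1-fold higher number from compound 1 to compound 3 (0.05 log units; within the scatter), a 2.0-fold higher number from compound 1 to compound 2 (0.30 log units; within the scatter) and, at the carbonyl carbon of that group, a 1.8-fold lower number from compound 2 to compound 3 (0.26 log units; within the scatter). Among the measured compounds shown here, each of them stayed within the scatter, although no measured compound carries an ether at this position. Compound 4 is therefore expected to give about 14 nM, with a range from 5 nM to 40 nM. The expected step is a 1.4-fold higher number from compound 3 to compound 4 (0.15 log units; within the scatter), no change beyond the scatter.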

Compound 4, half-maximal effective concentration: 1 nM
Estimate against measurement, compound 4: 14-fold (1.15 log units) above; the measured number lies below the stated range.
By their numbers in this assay, from the lowest: compound 4; then compounds 1, 3 and 2 (each within the scatter of the next).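

In this assay the saturated ring carbon proves able to shift the number beyond the scatter, which no earlier change there did: (4-fluorobenzyl)oxy gives steps (a 10-fold lower number from compound 3 to compound 4 (1.00 log units; beyond the scatter)), (an 18-fold lower number from compound 2 to compound 4 (1.26 log units; beyond the scatter)) and (a 9.0-fold lower number from compound 1 to compound 4 (0.95 log units; beyond the scatter)). Against phenylcarbamoyl, the entering group has the same number of heavy atoms but no hydrogen-bond donor, and compound 4 is the only ether shown. No measurement here bears on what lies behind this gain. On these data alone, whether a benzylamino group would keep the low number remains open, as does whether an unsubstituted benzyloxy group would.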